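The source may report more compounds than this note shows. Statements on the series, on what has been measured and on what is new or still open speak of the compounds shown alone.

Measured compounds:
compound 1 `O=C(CCC1=CCN(Cc2ccc(F)cc2)C1=O)NO` — 130 mL/min/kg
compound 2 `O=C(CCC1=CCN(Cc2ccc(Br)cc2)C1=O)NO` — 71.7 mL/min/kg

Both compounds share one core and differ only in the group on the aromatic carbon. In an in vivo ADME assay on the whole organism (strain Balb/c) for pharmacokinetics, with Mus musculus as the target, at a dose of 10 mg/kg by the intravenous route (a lower number here means slower removal, a higher number faster removal of the compound), compound 1 gives 130 mL/min/kg, and in this assay compound 2 gives 71.7 mL/min/kg. Among the compounds with values here, the single measured step, a 1.8-fold lower number from compound 1 to compound 2 (0.26 log units; within the scatter), is within the scatter, so compound 2 stands together with compound 1 and the two numbers cannot be told apart.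

The unmeasured compound 3 `CC(C)(C)c1ccc(CN2CC=C(CCC(=O)NO)C2=O)cc1` takes the next step from compound 2: tert-butyl in place of bromo on an aromatic carbon. No measured step swaps a halogen for a carbon group of this kind, so nothing shown bears directly on this change. Within the data shown here, the one step that exists, a 1.8-fold lower number from compound 1 to compound 2 (0.26 log units; within the scatter), shows that exchanging one group at this position for another left the number within the scatter. On that basis no step beyond the scatter is expected in this assay.

Compound 3 is therefore estimated to give 75 mL/min/kg, with a range from 35 mL/min/kg to 160 mL/min/kg. That estimate means a step of a 1.0-fold higher number from compound 2 to compound 3 (0.02 log units; within the scatter), expected to remain within the scatter.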

Compound 3, clearance: 48.3 mL/min/kg
Compound 3: middle estimate off by 1.6-fold (0.19 log units), on the high side, and the stated range covers the measured number.
By their numbers in this assay, from the lowest: compounds 3, 2 and 1 (each within the scatter of the next, the first and the last beyond it).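

In this assay, tert-butyl on this aromatic carbon introduces a carbon group where the earlier pair held only halogens, and a 1.5-fold lower number from compound 2 to compound 3 (0.17 log units; within the scatter). Tert-butyl, with 4 heavy atoms, therefore cannot be told apart from bromo, with 1 heavy atom, in this measurement. The comparison with fluoro gives the first difference at this position that clears the scatter, as a 2.7-fold lower number from compound 1 to compound 3 (0.43 log units; beyond the scatter), so this exchange has a real but modest effect on clearance, and no measured information accounts for it.

On these data alone, the three compounds carry only fluoro, bromo and tert-butyl at this place, so it remains open how an amine, a carboxylic acid or a longer chain there would compare. The rest of the shared core is identical throughout, which also leaves open how clearance would respond to a change anywhere else in the molecule.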